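The compounds below may be only part of what the source reports. "The series", "measured", "known", "first", "only" and "open" are said of these compounds alone.

Measured compounds:
compound 1 `CCOc1c(NC)cnn(C)c1=O`: 31.1%
compound 2 `CCOc1c(N2CCCC2)cnn(C)c1=O`: 23%

In a functional assay on the whole organism (strain Wistar) for inhibition, with Rattus norvegicus as the target, read by paw edema, with stated times of 30 min and 3 h, at a dose of 100 mg/kg by the oral route (a lower number here means a weaker effect, a higher number a stronger effect of the compound at the dose given), compound 1 gives 31.1%, the highest of the two numbers shown, though its nearest neighbour compound 2 lies within the scatter, the step being a number 8.1 percentage points lower from compound 1 to compound 2 (within the scatter). Compound 3 `CCOc1c(Nc2ccccc2)cnn(C)c1=O` differs from compound 1 by phenyl in place of methyl on a nitrogen on an aromatic ring. For the measured compounds named here, the only measured step that bears on this change is the one from compound 1 to compound 2, which also alters the nitrogen attached to the shared core and which stayed within the scatter at a number 8.1 percentage points lower from compound 1 to compound 2 (within the scatter). Going by the values given here, no measured step exchanges methyl for phenyl on that nitrogen, so the evidence is thin. On what the data show, compound 3 is expected to give about 27% in this assay, with a range from 8% to 46%. For compound 3 this means an expected step of a number 4.1 percentage points lower from compound 1 to compound 3 (within the scatter), not beyond the scatter.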

Compound 3, a percentage reported as inhibition, in the whole organism at one dose (the size of the read-out at that dose, not a potency): 4.9%
Compound 3: middle estimate off by 22.1 percentage points, on the high side; the whole stated range lies above it.
By their numbers in this assay, from the lowest: compound 3; then compounds 2 and 1 (each within the scatter of the next).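

In this assay, putting phenyl in place of methyl on the nitrogen gives a number 26.2 percentage points lower from compound 1 to compound 3 (beyond the scatter), so this position does respond to the group it carries. The earlier pair could not show this, since the step of a number 8.1 percentage points lower from compound 1 to compound 2 (within the scatter) left the change from methylamino to pyrrolidin-1-yl unresolved from the scatter; the nitrogen therefore tolerates that exchange within the scatter, while the aromatic ring of compound 3 brings a clear drop at the dose given. Nothing available explains why phenyl behaves this way here.

The compounds shown leave open whether the drop belongs to the aromatic ring itself or to any larger group on that nitrogen, which a benzyl group or a cyclohexyl ring could begin to separate. They also leave open whether a phenyl ring bearing a chlorine or a methoxy group would fall as far as compound 3.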